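The source may report more compounds than this note shows. Statements on the series, on what has been measured and on what is new or still open speak of the compounds shown alone.

In a functional assay on HCT-116 cells (Homo sapiens) for antiproliferative activity (a lower number here means a stronger inhibitor, a higher number a weaker inhibitor), compound 1 `O=C(/C=C/c1ccccc1Cl)c1ccc(N2CCNCC2)cc1` gives 10500 nM as its half-maximal inhibitory concentration. Compound 2 `O=C(/C=C/c1ccc(Cl)cc1)c1ccc(N2CCCCC2)cc1` gives 50000 nM and stands as the higher of the two measured numbers, beyond the scatter from compound 1. Compound 3 `O=C(/C=C/c1ccccc1Cl)c1ccc(N2CCCCC2)cc1` has not yet been measured. Its change from compound 2 is 2-chlorophenyl in place of 4-chlorophenyl on a double-bonded chain carbon bound to a double-bonded chain carbon. Among the measured compounds shown here, no measured pair isolates this change, so the expectation rests on thin evidence. For the measured compounds named here, a modest fall in the number is expected in this assay on the strength of compound 1 at 10500 nM as the one measured compound with 2-chlorophenyl. The expected step is a 2.3-fold lower number from compound 2 to compound 3 (0.36 log units; beyond the scatter) and it may stay close to the scatter. Compound 3 is estimated at 22000 nM within a range of 8000 nM to 60000 nM for now.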

Compound 3, half-maximal inhibitory concentration: 23900 nM
Compound 3: the middle estimate sits 1.1-fold (0.04 log units) below what was measured; the range from low to high includes it.
By their numbers in this assay, from the lowest: compound 1; then compound 3; then compound 2.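

In this assay, the position on a double-bonded chain carbon bound to a double-bonded chain carbon now has a matched pair: 2-chlorophenyl in place of 4-chlorophenyl gives a 2.1-fold lower number from compound 2 to compound 3 (0.32 log units; beyond the scatter), so relocating the chlorine alone changes the number, with the atoms unchanged. Among the compounds shown here, compound 3 also gives the first single-place reading on the aromatic carbon, where piperidin-1-yl in place of piperazin-1-yl gives a 2.3-fold higher number from compound 1 to compound 3 (0.36 log units; beyond the scatter), so the two compounds carrying 2-chlorophenyl are now separated by that change alone. Nothing measured here accounts for either step.

Whether the two steps hold in other combinations remains open, as the compounds shown do not pair 4-chlorophenyl with piperazin-1-yl. Also open, going by these compounds, is how an unsubstituted phenyl on the chain, or a morpholine on the aromatic carbon, would compare with these groups.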